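Replacing Cyclohexyl with 4-Fluorophenyl on the Piperazine Nitrogen

The source may report more compounds than this note shows. Statements on the series, on what has been measured and on what is new or still open speak of the compounds shown alone.

Measured compounds:
compound 1, `Nc1ccccc1NC(=O)c1ccc(CSC(=S)N2CCN(C3CCCCC3)CC2)cc1`, 31.7%;
compound 2, `CC1CCCCN1C(=S)SCc1ccc(C(=O)Nc2ccccc2N)cc1`, 42.5%;
compound 3, `CN(Cc1ccncc1)C(=S)SCc1ccc(C(=O)Nc2ccccc2N)cc1`, 31.4%.

Three compounds sharing one core were tested in a functional assay on A-375 cells (Homo sapiens) for antiproliferative activity, read by CCK-8 assay, with a stated time of 72 h, tested at 2 uM; a lower number here means a weaker effect, a higher number a stronger effect of the compound at the concentration tested. Compound 1 gives 31.7%, the second highest of the three numbers. Its nearest neighbour is compound 3, whose value of 31.4% lies within the scatter of that of compound 1. Compound 2, with 42.5%, stands beyond the scatter above compound 1.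

Compound 4, `Nc1ccccc1NC(=O)c1ccc(CSC(=S)N2CCN(c3ccc(F)cc3)CC2)cc1`, has not yet been measured. It differs from compound 1 in one place: 4-fluorophenyl in place of cyclohexyl on an amine nitrogen in a ring.

Going by the values given here, the only measured step, a number 11.1 percentage points lower from compound 2 to compound 3 (beyond the scatter), changes the group on the thiocarbonyl carbon, not the group on the amine nitrogen in the ring, so no measured step bears directly on the change from compound 1 to compound 4. That single step was modest in size, and the three values lie close together. The expected step is therefore small, a number 3.3 percentage points higher from compound 1 to compound 4 (within the scatter), with no firm direction. The estimate for compound 4 in this assay is 35%, expected to fall between 20% and 52%.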

Compound 4, a percentage reported as inhibition, at one concentration (the size of the read-out at that concentration, not a potency): 20.9%
Beside the measured number, compound 4's estimate is 14.1 percentage points above it; measured number inside the range.
By their numbers in this assay, from the lowest: compound 4; then compounds 3 and 1 (each within the scatter of the next); then compound 2.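

On the amine nitrogen in the ring, this assay records a number 10.8 percentage points lower from compound 1 to compound 4 (beyond the scatter) when 4-fluorophenyl enters in place of cyclohexyl. Going by these compounds alone, the group on this nitrogen therefore affects the read-out, which the earlier compounds could not show, as their one step, a number 11.1 percentage points lower from compound 2 to compound 3 (beyond the scatter), changed the group on the thiocarbonyl carbon instead. This single change both replaces a non-aromatic carbon ring with an aromatic one and introduces fluorine, so the two cannot be told apart here.

From the compounds shown here alone, it remains open whether an unsubstituted phenyl, a 4-methoxyphenyl or a simple methyl on this nitrogen would give a number nearer that of compound 1 or that of compound 4. Nothing measured here accounts for the step from cyclohexyl to 4-fluorophenyl.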